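The source may hold more compounds than are shown below. What is called first, only, known or untested is meant among the compounds shown, and "the series" means these compounds.

The measured compounds:
Compound 1 `CNC(=O)c1cc(Oc2ccc(NC(=O)c3nn(-c4ccccc4C(F)(F)F)c(=O)cc3C)cc2F)ccn1`. In a functional assay on A549 cells (Homo sapiens) for cytotoxicity, read by MTT assay, with a stated time of 72 h (on this read-out higher numbers stand for weaker inhibition and lower numbers for stronger inhibition), compound 1 gives > 40000 nM, which is a limit of the assay rather than a number.
Compound 2 `Cc1cc(=O)n(-c2ccc(Br)cc2F)nc1C(=O)Nc1ccc(Oc2ncnc3ccsc23)cc1`. In this assay compound 2 gives 7930 nM.
Compound 3 `Cc1cc(=O)n(-c2ccc(Br)cc2F)nc1C(=O)Nc1ccc(Oc2ncnc3sccc23)cc1`. In this assay compound 3 gives 12800 nM.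

Among the measured compounds shown here, compound 3 holds the highest of the two numbers, but its only neighbour is compound 2, and the step of a 1.6-fold higher number from compound 2 to compound 3 (0.21 log units; within the scatter), a swap of the bicyclic ether group, stays within the scatter. Compound 4 `Cc1cc(=O)n(-c2ccc(F)cc2)nc1C(=O)Nc1ccc(Oc2ncnc3sccc23)cc1` differs from compound 3 by 4-fluorophenyl in place of 4-bromo-2-fluorophenyl on an aromatic nitrogen. For the measured compounds named here, no measured step touches that ring; the one measured step, a 1.6-fold higher number from compound 2 to compound 3 (0.21 log units; within the scatter), changes a different part of the molecule and gives no direct guide. Without such a guide, only a modest shift is expected. Compound 4 is expected to give 20000 nM in this assay, between 6000 nM and 60000 nM. That estimate means an expected step of a 1.6-fold higher number from compound 3 to compound 4 (0.19 log units; within the scatter).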

Compound 4, half-maximal inhibitory concentration: 7050 nM
Compound 4: the middle estimate sits 2.8-fold (0.45 log units) above what was measured, within the range that was stated.
By their numbers in this assay, from the lowest: compounds 4, 2 and 3 (each within the scatter of the next). At a limit, above all of these: compound 1.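

Among the compounds shown here, this is the first measured change at the aromatic nitrogen: in this assay, 4-fluorophenyl in place of 4-bromo-2-fluorophenyl gives a 1.8-fold lower number from compound 3 to compound 4 (0.26 log units; within the scatter). Removing the bromine and one fluorine therefore leaves the reading within the scatter, so this swap has no readable effect here. Nothing measured for these compounds explains why this step is so small.
Going by these compounds, whether the bromine or the second fluorine alone would matter remains open. So does what a pyridine ring or a benzyl group on that nitrogen would give.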